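This account rests on a few compounds, and the source may have more. Where it says the series, first, only, none or still open, it means among the compounds named here.

Compound 1 `Nc1ncnn2c([C@@H]3O[C@H](CO)[C@@H](O)[C@H]3O)cc(C#Cc3cccs3)c12` and compound 2 `Nc1ncnn2c([C@@H]3O[C@H](CO)[C@@H](O)[C@H]3O)cc(-c3ccccc3)c12` share one core and differ at a single aromatic carbon. In a functional assay on NCI-H460 cells (Homo sapiens) for antiproliferative activity, with a stated time of 72 h (a higher number here means a weaker inhibitor, a lower number a stronger inhibitor), compound 1 gives 26600 nM. For compound 2 the measurement reached only the limit of the assay, > 100000 nM, so no number is known for it. The step of an at least 3.7-fold higher number from compound 1 to compound 2 (0.57 log units; beyond the scatter) therefore rests on a limit rather than on two numbers, as shown by the limit of > 100000 nM in this assay, at which 1 of the 2 values shown sits, and compound 2 stands at the weak end of what these two values show.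

Compound 3 `COc1ccc(-c2cc([C@@H]3O[C@H](CO)[C@@H](O)[C@H]3O)n3ncnc(N)c23)cc1` is not yet measured. Relative to compound 2 it carries methoxy in place of hydrogen on an aromatic carbon. For the measured compounds named here, no measured step bears on this kind of change: the only known step, from the alkyne-bearing compound 1 to the phenyl-bearing compound 2, concerns a different replacement and says nothing about a substituent on the phenyl itself. With compound 2 already at the limit, it is expected that the step of a number no higher from compound 2 to compound 3 (the limit leaves the size open) will not move compound 3 beyond the scatter in this assay. Compound 3 is estimated at 100000 nM, in a range from 30000 nM to 300000 nM, with a substantial chance that only a limit is again reported.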

Compound 3, half-maximal inhibitory concentration: 69300 nM
Estimate against measurement, compound 3: 1.4-fold (0.16 log units) above; the range from low to high includes it.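

With 4-methoxyphenyl on this aromatic carbon, the comparison with the 2-(thiophen-2-yl)ethynyl group in this assay now rests on two numbers rather than a limit, and it reads a 2.6-fold higher number from compound 1 to compound 3 (0.42 log units; beyond the scatter). Methoxy in place of hydrogen, para to a large group on the phenyl, gives an at least 1.4-fold lower number from compound 2 to compound 3 (0.15 log units; that floor lies within the scatter). The true size of that step stays open because compound 2 carries only a limit, so it cannot be said whether the methoxy changes the activity beyond the scatter: the limit of > 100000 nM in this assay, at which 1 of the 3 values shown sits.

The compounds shown leave open whether the difference between compound 1 and compound 3 belongs to the ethynyl link or to the thiophene, which a phenyl carried on an ethynyl link would help to separate. They also leave open how an amine, a carboxylic acid or a longer chain such as ethoxy would read in the place of the methoxy on this phenyl.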